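The source may hold more compounds than are shown below. What is called first, only, known or untested is meant among the compounds shown, and "the series" means these compounds.

The series shares the core of compound 1 `CCC(C)n1nc(C)cc1NC(=O)Cn1nnc(-c2ccccc2)n1` and varies only the group on an aromatic nitrogen. In an assay on HEK293 cells for activation of Kir3.1/Kir3.2 (Homo sapiens), read by thallium flux (a higher number here means a larger maximal response, a lower number a smaller maximal response), compound 1 gives only a limit, > 69%. Compound 2 `Cc1cc(NC(=O)Cn2nnc(-c3ccccc3)n2)n(C2CCCC2)n1` gives 105% in this assay. Compound 3 `Cc1cc(NC(=O)Cn2nnc(-c3ccccc3)n2)n(C2CCS(=O)(=O)C2)n1` gives 93% in this assay, the lowest of the two numbers, set apart from compound 2 by a number 12 percentage points lower from compound 2 to compound 3 (beyond the scatter). Compound 4 `Cc1cc(NC(=O)Cn2nnc(-c3ccccc3)n2)n(CC2CCCCC2)n1` is not yet measured; the change is cyclohexylmethyl in place of 1,1-dioxothiolan-3-yl on an aromatic nitrogen. Among the measured compounds shown here, the one readable step bearing on it is a number 12 percentage points lower from compound 2 to compound 3 (beyond the scatter); the steps from compound 1 stay unreadable because of the limit of > 69% in this assay, at which 1 of the 3 values shown sits. A rise back toward the carbon-only ring value of compound 2 is expected, a number 9 percentage points higher from compound 3 to compound 4 (within the scatter). Compound 4 is estimated at 102% in this assay, between 88% and 116%.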

Compound 4, largest response reached (Emax), in percent of the reference or control that the assay uses: 77%
Estimate against measurement, compound 4: 25 percentage points above, and the stated range ends above it.
By their numbers in this assay, from the lowest: compound 4; then compound 3; then compound 2.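

At this place on the aromatic nitrogen, a carbon-only group does not by itself keep the response in this assay: cyclohexylmethyl gives a number 16 percentage points lower from compound 3 to compound 4 (beyond the scatter), and set against cyclopentyl it gives a number 28 percentage points lower from compound 2 to compound 4 (beyond the scatter). The 1,1-dioxothiolan-3-yl group therefore no longer marks the low end of the series, and a carbon-only ring can lie on either side of it. The steps from compound 1 cannot be read: the limit of > 69% in this assay, at which 1 of the 4 values shown sits.

Going by these compounds, what cyclohexyl or cyclopentylmethyl would give on this nitrogen stays open. The compounds shown do not separate ring size from the carbon link between ring and nitrogen.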